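Three Weak Inhibitors and an Untested Dimethoxy Analogue

The source may hold more compounds than are shown below. What is called first, only, known or untested is meant among the compounds shown, and "the series" means these compounds.

Compound 1 `O=C(NCC1CCCCC1)c1cccc(/C=C2\CC(=O)N(c3ccccc3)C2=O)c1`: in an ADME assay on SW480 cells (Homo sapiens) for cytotoxicity, read by MTT assay, with a stated time of 72 h (a lower number here means a stronger inhibitor, a higher number a weaker inhibitor), compound 1 gives > 100000 nM, a limit of the assay.
Compound 2 `Cc1ccc(NC(=O)c2cccc(/C=C3\CC(=O)N(c4ccccc4)C3=O)c2)cc1C`: in this assay compound 2 gives > 100000 nM, a limit of the assay.
Compound 3 `CCc1cccc(NC(=O)c2cccc(/C=C3\CC(=O)N(c4ccccc4)C3=O)c2)c1`: in this assay compound 3 gives 88600 nM.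

Among the compounds with values here, compound 3 thus holds the only true number of the three; the other two values are limits, as the limit of > 100000 nM in this assay, at which 2 of the 3 values shown sit, shows. Compound 4 `COc1ccc(OC)c(NC(=O)c2cccc(/C=C3\CC(=O)N(c4ccccc4)C3=O)c2)c1` differs from compound 3 by 2,5-dimethoxyphenyl in place of 3-ethylphenyl on an amide-type nitrogen. Within the data shown here, the steps that bear on this change are an at least 1.1-fold lower number from compound 1 to compound 3 (0.05 log units; that floor lies within the scatter) and an at least 1.1-fold lower number from compound 2 to compound 3 (0.05 log units; that floor lies within the scatter); both are floors within the scatter, so no step beyond the scatter is expected in this assay. For compound 4 the value expected in this assay is 100000 nM, with a range from 35000 nM to 300000 nM. The expected step is therefore a 1.1-fold higher number from compound 3 to compound 4 (0.05 log units; within the scatter), and a limit rather than a number is quite possible.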

Compound 4, half-maximal inhibitory concentration: > 100000 nM
Compound 4 gave a limit, no number (the forecaster's own chance of this, stated with the estimate: 55%); the middle value lies on the limit itself.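

In this assay, the change to 2,5-dimethoxyphenyl on the amide-type nitrogen gives an at least 1.1-fold higher number from compound 3 to compound 4 (0.05 log units; that floor lies within the scatter), so placing two hydrogen-bond acceptors on this aromatic ring produces no step shown to lie beyond the scatter. The steps from compound 1 and compound 2 to compound 4 cannot be read, and the upper limit now holds most of the set: the limit of > 100000 nM in this assay, at which 3 of the 4 values shown sit.

As far as these compounds go, it remains open whether any group on this nitrogen can give a value well inside the measurable range. A phenyl ring carrying an amine or a carboxylic acid would test this.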